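Aryl swap on the carbonyl: compound 3 to compound 4

This account rests on a few compounds, and the source may have more. Where it says the series, first, only, none or still open, it means among the compounds named here.

Three compounds share the core of compound 1 (`Cc1cccc(C(=O)Nc2cc(Cl)ccc2OCC(=O)Nc2ccc(S(N)(=O)=O)cc2C)c1`) and differ only in the aryl group on the carbonyl carbon. In a functional assay on C8166 cells (Homo sapiens) for cytotoxicity, read by MTT assay (a higher number here means that more compound is tolerated, a lower number that less compound is tolerated), compound 1 reads 52900 nM against compound 2 (`Cc1cc(S(N)(=O)=O)ccc1NC(=O)COc1ccc(Cl)cc1NC(=O)c1cccc(Cl)c1`) at 59700 nM and compound 3 (`Cc1ccc(C(=O)Nc2cc(Cl)ccc2OCC(=O)Nc2ccc(S(N)(=O)=O)cc2C)cc1C`) at 84100 nM with all three inside the scatter of one another. Compound 3 is therefore not separated from the others, the gaps to it being a 1.6-fold higher number from compound 1 to compound 3 (0.20 log units; within the scatter) and a 1.4-fold higher number from compound 2 to compound 3 (0.15 log units; within the scatter) in this set.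

The next change leads to compound 4 (`Cc1cc(S(N)(=O)=O)ccc1NC(=O)COc1ccc(Cl)cc1NC(=O)c1cc(Cl)cc(Cl)c1`) with 3,5-dichlorophenyl in place of 3,4-dimethylphenyl on a carbonyl carbon as the counted difference: 3,5-dichlorophenyl in place of 3,4-dimethylphenyl on a carbonyl carbon. Two kinds of measured change bear on it. Chloro in place of methyl on an aromatic carbon gave a 1.1-fold higher number from compound 1 to compound 2 (0.05 log units; within the scatter) as its step, and methyl in place of hydrogen on an aromatic carbon gave a 1.6-fold higher number from compound 1 to compound 3 (0.20 log units; within the scatter) as its step. Neither leaves the scatter, so no step beyond the scatter is expected in this assay and no direction can be claimed. The estimated step is a 1.2-fold lower number from compound 3 to compound 4 (0.09 log units; within the scatter) on this reasoning. Compound 4 is expected at 68000 nM (35000 nM to 130000 nM).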

Compound 4, half-maximal cytotoxic concentration: 72400 nM
Compound 4: middle estimate off by 1.1-fold (0.03 log units), on the low side, and the stated range covers the measured number.
By their numbers in this assay, from the lowest: compounds 1, 2, 4 and 3 (each within the scatter of the next).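

Working notes: with 3,5-dichlorophenyl on the carbonyl carbon, the series in this assay now includes an aryl group carrying two chloro substituents, and each comparison with compound 4 stays within the scatter (a 1.2-fold lower number from compound 3 to compound 4 (0.07 log units; within the scatter); a 1.2-fold higher number from compound 2 to compound 4 (0.08 log units; within the scatter); a 1.4-fold higher number from compound 1 to compound 4 (0.14 log units; within the scatter)). Two kinds of change not seen earlier therefore leave the number unresolved: adding a second chloro to the 3-chlorophenyl group of compound 2, and exchanging 3,4-dimethylphenyl for 3,5-dichlorophenyl, which keeps the heavy-atom count of the aryl group the same. No measurement available here accounts for this lack of separation.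

All the aryl groups shown are phenyl rings carrying only chloro or methyl, so it remains open how the number in this assay would respond to a carboxylic acid, an amine or a methoxy group on this ring, or to a pyridine ring in its place. Also open, on these data alone, is whether any group on this carbonyl carbon can produce a step beyond the scatter, and how changes elsewhere on the shared core would read.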